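The compounds below may be only part of what the source reports. "The series", "measured", "known", "first", "only" and "open" are said of these compounds alone.

Measured so far in an assay on isolated protein for activation of cGMP-dependent protein kinase 1 (Homo sapiens), read by ADP-Glo, with stated times of 30 min and 2 h; a higher number here means that more compound is needed for the effect, a lower number that less compound is needed:

- compound 1 `COC(=O)c1ccc(CN2CCC[C@H](O[C@H](CO)c3cc(Cl)cc(Cl)c3)[C@@H]2c2ccccc2)c(C)c1`: > 200000 nM, a limit of this assay and not a number
- compound 2 `OC[C@@H](O[C@H]1CCCN(Cc2ncc[nH]2)[C@H]1c1ccccc1)c1cc(Cl)cc(Cl)c1`: > 200000 nM, likewise a limit and not a number
- compound 3 `O=C(O)c1ccc(CN2CCC[C@H](O[C@H](CO)c3cc(Cl)cc(Cl)c3)[C@@H]2c2ccccc2)cc1`: 77000 nM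

Compound 3 holds the only number shown in this assay; the two other values sit at the limit (the limit of > 200000 nM in this assay, at which 2 of the 3 values shown sit). The change from compound 1 to compound 3 is at least a modest one, an at least 2.5-fold lower number from compound 1 to compound 3 (0.41 log units; beyond the scatter), and the same holds from compound 2 to compound 3, an at least 2.5-fold lower number from compound 2 to compound 3 (0.41 log units; beyond the scatter). Between compound 1 and compound 2 both values are limits, so that step cannot be read.

Compound 4 `O=C(O)c1ccc2nc(CN3CCC[C@H](O[C@H](CO)c4cc(Cl)cc(Cl)c4)[C@@H]3c3ccccc3)[nH]c2c1` is not yet measured. It differs from compound 3 in the group carried on the saturated chain carbon bound to the amine nitrogen in the ring: a group of 12 heavy atoms (8 carbon, 2 nitrogen, 2 oxygen; one five-membered aromatic ring with 2 hetero atoms, one six-membered aromatic ring of carbon only) in place of a group of 9 heavy atoms (7 carbon, 2 oxygen; one six-membered aromatic ring of carbon only), on a saturated chain carbon bound to an amine nitrogen in a ring. The entering group keeps the carboxylic acid of compound 3 and adds the five-membered aromatic ring with two hetero atoms that compound 2 also carries, and compound 2 stands only at a limit. Only the two readable steps bear on the change, and both point to the carboxylic acid as the part that brings a number into range, so no step beyond the scatter is expected from compound 3 to compound 4: a 1.3-fold lower number from compound 3 to compound 4 (0.11 log units; within the scatter). Compound 4 is estimated at 60000 nM in this assay, with a range from 15000 nM to 200000 nM.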

Compound 4, half-maximal effective concentration: 43000 nM
Compound 4: middle estimate off by 1.4-fold (0.14 log units), on the high side; the measured number falls inside the stated range.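

In this assay, the place on a saturated chain carbon bound to an amine nitrogen in a ring takes a group of 12 heavy atoms in place of 4-carboxyphenyl with no step beyond the scatter (a 1.8-fold lower number from compound 3 to compound 4 (0.25 log units; within the scatter)). The five-membered aromatic ring with 2 hetero atoms therefore does not keep a compound out of range when the group also carries a carboxylic acid (an at least 4.6-fold lower number from compound 2 to compound 4 (0.66 log units; beyond the scatter)), and the group of compound 4 likewise stands apart from that of compound 1 (an at least 4.6-fold lower number from compound 1 to compound 4 (0.66 log units; beyond the scatter)). Both of these last two steps start from a limit and not from a number: the limit of > 200000 nM in this assay, at which 2 of the 4 values shown sit.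

Among the compounds shown here, the only two numbers lie within the scatter of each other, so no change among measured values yet separates one acid-bearing group from the other at this place. As far as these compounds go, whether a primary amide or a tetrazole in place of the carboxylic acid keeps a number in range stays open, as does the effect of a longer chain between the amine nitrogen and the aromatic ring.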